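The source may hold more compounds than are shown below. What is called first, only, known or untested is meant among the compounds shown, and "the series" means these compounds.

Measured so far: compound 1 `Cc1cccc2nc(C(=O)C3(CCC(C)(C)C)CCNC3)ccc12` with 1 nM; compound 2 `O=C(c1ccc2[nH]ccc2c1)C1(Cc2ccccc2)CNC1` with 794 nM.

Both were tested in an assay on isolated protein for inhibition of sodium-dependent dopamine transporter (Homo sapiens); on this read-out higher numbers stand for weaker inhibition and lower numbers for stronger inhibition. Compound 1 gives the lower of the two numbers, and compound 2 with its 794 nM stands far beyond the scatter from it. Among the measured compounds shown here, no one-point step connects these two compounds, so their gap is simply noted as it stands. The unmeasured compound 3 `CC(C)(C)CCC1(C(=O)c2ccc3ccccc3n2)CCNC1` is compound 1 with a single change: hydrogen in place of methyl on an aromatic carbon. For the measured compounds named here, no measured pair shows what this change does here, so the expectation rests on compound 1 alone, whose 1 nM leaves little room for a lower number. In this assay the step of a 3.0-fold higher number from compound 1 to compound 3 (0.48 log units; beyond the scatter) is expected to be small and toward a higher number, within or only just beyond the scatter. Compound 3 is therefore estimated at 3 nM, with a range from 1 nM to 10 nM.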

Compound 3, inhibition constant: 3.98 nM
Compound 3: the middle estimate sits 1.3-fold (0.12 log units) below what was measured, and the stated range covers the measured number.
By their numbers in this assay, from the lowest: compound 1; then compound 3; then compound 2.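

Hydrogen in place of methyl on an aromatic carbon gives, in this assay, a 4.0-fold higher number from compound 1 to compound 3 (0.60 log units; beyond the scatter), the first one-point step among these compounds. It shows that this position, ortho to a fused ring and meta to a fused ring, has a measurable but modest bearing on the read-out: the methyl goes with the lower number, yet without it compound 3 still gives 3.98 nM, so the methyl is not required for a low number in this assay. No supporting measurement is available to explain this step.

The compounds shown leave open whether an ethyl group, a methoxy group or a chlorine atom on this aromatic carbon would give a lower or a higher number than methyl. This single pair also leaves open whether the step would be the same size on a different core.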